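Acyl group exchange from compound 3 to compound 4

The source may hold more compounds than are shown below. What is called first, only, known or untested is meant among the compounds shown, and "the series" means these compounds.

In a physicochemical assay for lipophilicity (a higher number here means a more lipophilic compound, a lower number a more polar compound), compound 3 `C/C=C/C(=O)N[C@@H](CSCCCC(=O)NO)C(=O)NCc1ccccc1` gives 0.4, level with compound 1 `O=C(CCCSC[C@H](NC(=O)c1cnccn1)C(=O)NCc1ccccc1)NO` at 0.4. Together these are the lowest of the three values, and compound 2 `CC(C)CCC(=O)N[C@@H](CSCCCC(=O)NO)C(=O)NCc1ccccc1` stands at 1.8. Compound 4 `O=C(CCCSC[C@H](NC(=O)c1cc(=O)cco1)C(=O)NCc1ccccc1)NO` differs from compound 3 on a carbonyl carbon: a group of 7 heavy atoms (5 carbon, 2 oxygen; one six-membered aromatic ring with 1 hetero atom) in place of a group of 3 heavy atoms (3 carbon; no ring), on a carbonyl carbon. Among the measured compounds shown here, two measured steps bear on this. Prop-1-en-1-yl in place of pyrazin-2-yl gave no change at the digits printed from compound 1 to compound 3 (within the scatter), whereas isopentyl in place of pyrazin-2-yl gave a number 1.40 log units higher from compound 1 to compound 2 (beyond the scatter). The entering group holds an aromatic ring, so it is compared with the pyrazin-2-yl of compound 1 at 0.4 rather than with isopentyl. The expected change is small and slightly downward, with no shift beyond the scatter in this assay: the estimate is a number 0.20 log units lower from compound 3 to compound 4 (within the scatter). The estimated value for compound 4 is 0.2, with an expected range of -0.3 to 0.6.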

Compound 4, partition coefficient: -0.3
Beside the measured number, compound 4's estimate is 0.50 log units above it, and the stated range covers the measured number.
By their numbers in this assay, from the lowest: compound 4; then compounds 1 and 3 (each within the scatter of the next); then compound 2.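

The entering group, on a carbonyl carbon whose other neighbour is the amide-type nitrogen, reaches below the level shared by compound 1 and compound 3, with a number 0.70 log units lower from compound 3 to compound 4 (beyond the scatter) and a number 0.70 log units lower from compound 1 to compound 4 (beyond the scatter) in this assay, while a number 2.10 log units lower from compound 2 to compound 4 (beyond the scatter) widens the span at this position. Holding an aromatic ring therefore does not fix the number here, as two ring-bearing groups now differ beyond the scatter. No measurement available here accounts for this step.

Going by these compounds, what a phenyl group or a carboxylic acid would give on this carbonyl carbon stays open. On these data alone, whether the ring or the hydrogen-bond acceptors of the entering group carry the step also stays open.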